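The source may report more compounds than this note shows. Statements on the series, on what has been measured and on what is new or still open speak of the compounds shown alone.

Measured compounds:
- compound 1, `CC1=C(O)[C@@H](C/C(C)=C\CCC(C)/C=C/C/C(C)=C/CCc2ccoc2)OC1=O`: 26.8 ug/mL
- compound 2, `CC1=C(O)/C(=C\[C@H](C)CCC/C(C)=C/CCc2coc(Cc3ccoc3)c2)OC1=O`: 9.39 ug/mL

Both compounds were tested in a functional assay on SK-OV-3 cells (Homo sapiens) for cytotoxicity; a higher number here means that more compound is needed for the effect, a lower number that less compound is needed. In this assay compound 1 gives 26.8 ug/mL, while compound 2 gives 9.39 ug/mL. Compound 2 therefore stands at the lower of the two numbers, and the gap between compound 1 and compound 2 is wider than the usual scatter of repeated measurements, so less of compound 2 is needed for the same effect.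

Compound 3, `CC1=C(O)/C(=C/[C@H](C)CCC/C(C)=C/CCc2coc(Cc3ccoc3)c2)OC1=O`, has not yet been measured. It is built from the same atoms and bonds as compound 2; the change is the two compounds have the same atoms and bonds and differ only in configuration as drawn: 1 of 3 stereo elements differ; a double bond is drawn E in compound 2 and Z in compound 3. Nothing else moves. Among the measured compounds shown here, no pair of measured compounds shows what flipping a drawn double bond does here, so the expectation can only be cautious. A change of this kind, with nothing added or removed, is expected to give either no step beyond the scatter or a modest one in either direction. The step expected from compound 2 to compound 3 in this assay is a 1.3-fold higher number from compound 2 to compound 3 (0.11 log units; within the scatter). On that basis compound 3 is estimated at 12 ug/mL, with a range from 5 ug/mL to 30 ug/mL.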

Compound 3, concentration for half-maximal effect: 6.55 ug/mL
The estimate for compound 3 lay 1.8-fold (0.26 log units) above the measured number; low and high end bracket the measured number.
By their numbers in this assay, from the lowest: compounds 3 and 2 (each within the scatter of the next); then compound 1.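

Among the compounds shown here, this pair gives the first reading of what flipping a drawn double bond does in this assay: the switch from E to Z comes with a 1.4-fold lower number from compound 2 to compound 3 (0.16 log units; within the scatter). At this double bond, then, the two drawn forms cannot be told apart in this assay, and neither can be called the better one. The comparison is a clean one, because nothing else separates the two compounds: the fact that compounds 2 and 3 differ only in the configuration as drawn

Compound 1 differs from both of these compounds in more than one place, so it adds nothing to this reading, and the other two stereo elements remain untested here, so it is open whether flipping either of them would also stay within the scatter. Also open, from the compounds shown here alone, is whether a larger change would give a step beyond the scatter, such as a longer chain, or an amine or a carboxylic acid in place of the hydroxyl group on the shared core.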